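The source may hold more compounds than are shown below. What is called first, only, known or untested is meant among the compounds shown, and "the series" means these compounds.

Measured compounds:
compound 1, `NC(=O)/C=C/c1ccncc1-c1ccc2ccccc2c1`: 10.5 nM
compound 2, `CNC(=O)CCc1ccncc1-c1ccc2ccccc2c1`: 21.1 nM
compound 3, `O=C(O)CCc1ccncc1-c1ccc2ccccc2c1`: 50.5 nM

All three were tested in an assay on a protein complex for inhibition of CDK8/Cyclin C (Homo sapiens), with a stated time of 1 h; a higher number here means a weaker inhibitor, a lower number a stronger inhibitor. Compound 1 has the lowest number of the three, though the gap to compound 2 is only a 2.0-fold higher number from compound 1 to compound 2 (0.30 log units; within the scatter), which does not separate the two; the gap to compound 3 is a 4.8-fold higher number from compound 1 to compound 3 (0.68 log units; beyond the scatter) and does.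

Compound 4, `CN1CCN(C(=O)/C=C/c2ccncc2-c2ccc3ccccc3c2)CC1`, keeps the double-bonded chain of compound 1 and changes only the amide end: 4-methylpiperazin-1-yl in place of amino on a carbonyl carbon. The measured step that speaks most directly to a change at the carbonyl carbon is a 2.4-fold higher number from compound 2 to compound 3 (0.38 log units; beyond the scatter), a modest loss. The step of a 2.0-fold higher number from compound 1 to compound 2 (0.30 log units; within the scatter), which also alters the amide substituent, stays within the scatter. Both steps therefore point to the amide end tolerating change without large swings in this assay, and neither involves a group as large as the one entering here. A small step is expected for compound 4, in the weakening direction if any, and the step from compound 1 to compound 4 is estimated at a 1.9-fold higher number from compound 1 to compound 4 (0.28 log units; within the scatter). Compound 4 is accordingly expected to give about 20 nM, between 8 nM and 50 nM.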

Compound 4, half-maximal inhibitory concentration: 43.6 nM
Estimate against measurement, compound 4: 2.2-fold (0.34 log units) below; the measured number falls inside the stated range.
By their numbers in this assay, from the lowest: compounds 1 and 2 (each within the scatter of the next); then compounds 4 and 3 (each within the scatter of the next).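

In this assay, among the compounds shown here, the change on the carbonyl carbon of the double-bonded chain gives a 4.2-fold higher number from compound 1 to compound 4 (0.62 log units; beyond the scatter), a modest step beyond the scatter, and the earlier steps could not show this because none of them brought a ring onto that carbon. It also shows that this place does not lose binding altogether when seven heavy atoms, including a six-membered non-aromatic ring, enter for a single nitrogen and the hydrogen-bond donor of the amino group leaves: compound 4 still reads 43.6 nM. No measurement at hand explains the step, so it cannot be assigned to the ring, the added atoms or the lost donor.

The compounds shown leave open how a morpholin-4-yl or a dimethylamino group on the same carbonyl carbon would read, which would help separate the effect of the ring from that of its methylated nitrogen. Also open, from the compounds shown here alone, is whether 4-methylpiperazin-1-yl gives a step of similar size when carried on the saturated chain of compound 2 rather than on the double-bonded chain.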